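The compounds below may be only part of what the source reports. "The series", "measured", "known", "first", "only" and "open" are said of these compounds alone.

Among the measured compounds shown here, compound 2 `O=C1[C@@H](n2cc(-c3ccccc3)nn2)[C@@H](/C=C/c2ccccc2)N1C1CCCCC1` holds the lowest of the two numbers measured so far in a functional assay on KB cells (Homo sapiens) for inhibition; a lower number here means a stronger inhibitor, a higher number a weaker inhibitor: compound 2 gives 8360 nM, while compound 1 `Cc1ccc(N2C(=O)[C@@H](n3cc(-c4ccccc4)nn3)[C@H]2/C=C/c2ccccc2)cc1` gives 89200 nM. Compound 3 `O=C1[C@@H](n2cc(-c3ccccc3)nn2)[C@@H](/C=C/c2ccccc2)N1c1ccc(Cl)cc1` differs from compound 2 in one place: 4-chlorophenyl in place of cyclohexyl on an amide-type nitrogen in a ring. For the measured compounds named here, only one measured step bears on this, and it runs the other way, an 11-fold lower number from compound 1 to compound 2 (1.03 log units; beyond the scatter), where an aromatic ring on that nitrogen carried the weaker number. A step back toward a higher number is therefore expected for compound 3, roughly a 4.8-fold higher number from compound 2 to compound 3 (0.68 log units; beyond the scatter). Compound 3 is estimated at 40000 nM, with a likely range from 10000 nM to 150000 nM.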

Compound 3, half-maximal inhibitory concentration: 84200 nM
Beside the measured number, compound 3's estimate is 2.1-fold (0.32 log units) below it; low and high end bracket the measured number.
By their numbers in this assay, from the lowest: compound 2; then compounds 3 and 1 (each within the scatter of the next).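

In this assay, 4-chlorophenyl on the amide-type nitrogen gives a 10-fold higher number from compound 2 to compound 3 (1.00 log units; beyond the scatter) and so shows that the weaker result is not confined to 4-methylphenyl. Chloro in place of methyl on an aromatic carbon gives a 1.1-fold lower number from compound 1 to compound 3 (0.03 log units; within the scatter) and leaves these two aromatic compounds indistinguishable. Nothing here gives a measured reason for the gap between cyclohexyl and these aromatic groups. Still open, from the compounds shown here alone, is whether the stronger number belongs to cyclohexyl alone or extends to other non-aromatic groups on that nitrogen, such as cyclopentyl, a hexyl chain or a cyclohexyl ring carrying an amine.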